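This account rests on a few compounds, and the source may have more. Where it says the series, first, only, none or still open, it means among the compounds named here.

Values in an ADME assay on HEp-2 cells (Homo sapiens) for cytotoxicity; a lower number here means that less compound is tolerated, a higher number that more compound is tolerated:
- Compound 1 `CNCc1ccc2c(c1)nc(Cn1c(=O)n(C(C)C)c3ccccc31)n2CCC(C)C`: 1480 nM
- Compound 2 `C=Cc1ccc2c(c1)nc(Cn1c(=O)n(C(C)C)c3ccccc31)n2CCC(C)C`: 6520 nM
- Compound 3 `CCc1ccc2c(c1)nc(Cn1c(=O)n(C(C)C)c3ccccc31)n2CCC(C)C`: 18500 nM

The three compounds share one core and differ only in the group on one aromatic carbon. Compound 3 has the highest number of the three, and both of its gaps to the others lie beyond the scatter.

The next compound is compound 4 `COC(=O)c1ccc2c(c1)nc(Cn1c(=O)n(C(C)C)c3ccccc31)n2CCC(C)C`, which carries methoxycarbonyl in place of ethyl on an aromatic carbon. For the measured compounds named here, no measured compound carries this group, so the measured steps bear on it only indirectly. The closest guide is a 2.8-fold higher number from compound 2 to compound 3 (0.45 log units; beyond the scatter), for ethyl in place of vinyl. The wider steps are a 4.4-fold higher number from compound 1 to compound 2 (0.64 log units; beyond the scatter) and a 13-fold higher number from compound 1 to compound 3 (1.10 log units; beyond the scatter). Going by the values given here, both other groups measured at this carbon sit lower than ethyl, with no compound against that so far, though three compounds are a thin basis.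

A modest step to a lower number in this assay is therefore expected, closer in size to the vinyl step than to the large one. The estimated change is a 2.1-fold lower number from compound 3 to compound 4 (0.31 log units; beyond the scatter). For compound 4 the expected value is 9000 nM, with an estimated range of 3000 nM to 25000 nM.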

Compound 4, half-maximal cytotoxic concentration: 33700 nM
Compound 4: the middle estimate sits 3.7-fold (0.57 log units) below what was measured; the whole stated range lies below it.
By their numbers in this assay, from the lowest: compound 1; then compound 2; then compounds 3 and 4 (each within the scatter of the next).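

In this assay, methoxycarbonyl on this aromatic carbon cannot be told apart from ethyl, with a 1.8-fold higher number from compound 3 to compound 4 (0.26 log units; within the scatter), even though the entering group has 4 heavy atoms and 2 hydrogen-bond acceptors and the leaving group has 2 heavy atoms and no acceptors. Methoxycarbonyl also stands clear of the other two groups, with a 5.2-fold higher number from compound 2 to compound 4 (0.71 log units; beyond the scatter) and a 23-fold higher number from compound 1 to compound 4 (1.36 log units; beyond the scatter), so vinyl and (methylamino)methyl remain the only groups at this carbon with clearly lower numbers, and the first group with hydrogen-bond acceptors and a carbonyl does not join them. Nothing available accounts for this ordering of the four groups.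

From the compounds shown here alone, it remains open whether ethyl and methoxycarbonyl mark an upper level for this carbon, and whether the low number of compound 1 goes with its amine, which a carboxylic acid, a primary amide or a dimethylamino group at the same carbon would help to settle. The compounds shown also leave open whether this ordering of groups would hold if the rest of the shared core were changed.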